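The source may hold more compounds than are shown below. What is called first, only, known or untested is meant among the compounds shown, and "the series" means these compounds.

Compound 1 `O=S(=O)(C1CC1)N1CCc2nc(C#Cc3ccccc3)sc2C1`: in an assay on HEK293 cells for positive allosteric modulation of metabotropic glutamate receptor 5 (Homo sapiens), read by FLIPR, with a stated time of 1 h (a lower number here means that less compound is needed, a higher number that more compound is needed for the effect), compound 1 gives > 10000 nM, which is a limit of the assay and not a number.
Compound 2 `O=S(=O)(C1CCCCC1)N1CCc2nc(C#Cc3ccccc3)sc2C1`: in this assay compound 2 gives > 10000 nM, again a limit of the assay and not a number.

Compound 2 thus stands at the limit, and both values shown sit there, as the limit of > 10000 nM in this assay, at which 2 of the 2 values shown sit, records. Going by the values given here, the one measured step, a step that the two limits leave unreadable from compound 1 to compound 2, is left unreadable by the two limits, so no size can be taken from it.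

Compound 3 `O=S(=O)(N1CCCCC1)N1CCc2nc(C#Cc3ccccc3)sc2C1` differs from compound 2 in one place: piperidin-1-yl in place of cyclohexyl on a sulfonyl sulfur. Among the compounds with values here, the only step that touches this sulfonyl sulfur is the unreadable one from compound 1 to compound 2, so no measured step gives a direction or a size for this change. Compound 3 is therefore expected to sit at the limit as well, with an estimate of 10000 nM and a range from 3000 nM to 30000 nM. The step this estimate implies, a number no higher from compound 2 to compound 3 (the limit leaves the size open), is expected to be none beyond the scatter.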

Compound 3, half-maximal effective concentration: > 10000 nM
Compound 3 gave a limit, no number; the forecaster's own chance of this, stated with the estimate: 80%; the middle value lies on the limit itself.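

Compound 3 also gives a limit of the assay and not a number, so none of the steps among compound 1, compound 2 and compound 3 can be read: the limit of > 10000 nM in this assay, at which 3 of the 3 values shown sit. The compounds shown leave open whether the groups on the sulfonyl sulfur differ at all in this assay, and by how much.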